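A few compounds are considered here, and "the series" means these few. Any claim that something is new, unique, unknown or untested is made for them only; others in the source may bear on it.

Going by the values given here, compound 2 `CCCCCCCCCCc1nc(N(C)C)c(C)c(C)c1O` is the stronger of the two compounds measured so far: in a functional assay on cells (Lymphocyte, Homo sapiens), read by trypan blue exclusion, with a stated time of 16 h, tested at 0.1 uM (a lower number here means a weaker effect, a higher number a stronger effect of the compound at the concentration tested), compound 2 gives 36%, and compound 1 `Cc1c(N(C)C)nc(CCCCCCCCCCO)c(O)c1C` gives 17%. Among the compounds with values here, the only measured step, a number 19 percentage points higher from compound 1 to compound 2 (beyond the scatter), concerns the far end of the long chain. Compound 3 `CCCCCCCCCCCCCCCCCCCc1nc(N(C)C)c(C)c(C)c1O` is built from compound 2 by nonyl in place of hydrogen on a saturated chain carbon, ten or more bonds along the chain from an aromatic carbon. That step sits at the same place on the chain as the measured one, but it lengthens the chain rather than removing a hydroxy group, so the measured step gives only an indirect guide; the data contain no lengthening of the chain itself. The expectation for compound 3 is therefore a step of a number 6 percentage points lower from compound 2 to compound 3 (within the scatter), within or close to the scatter, leaning slightly downward. Compound 3 is estimated to give 30% in this assay, with a range from 12% to 50%.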

Compound 3, a percentage reported as activity, at one concentration (the size of the read-out at that concentration, not a potency): 17%
Beside the measured number, compound 3's estimate is 13 percentage points above it; low and high end bracket the measured number.
By their numbers in this assay, from the lowest: compounds 1 and 3 (each within the scatter of the next); then compound 2.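

In this assay, the far end of the chain proves sensitive to lengthening as well as to the loss of hydroxy: nonyl in place of hydrogen lowers the read-out (a number 19 percentage points lower from compound 2 to compound 3 (beyond the scatter)), so compound 2, with plain hydrogen at this place, now stands above both of the other compounds. Nonyl in place of hydroxy leaves the read-out level (no change at the digits printed from compound 1 to compound 3 (within the scatter)), so two very different groups at this place give the same reading at this one concentration. Nothing shown offers a reason for these numbers.

Chains of intermediate length between those of compound 2 and compound 3 remain open, as does the effect of an amine or a carboxylic acid at the chain end. Whether the same order would hold at other concentrations also stays unresolved.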